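The source may hold more compounds than are shown below. What is called first, only, known or untested is meant among the compounds shown, and "the series" means these compounds.

Measured compounds:
- compound 1 `O=C(COc1ccc(/C=C2\SC(=O)NC2=O)cc1)Nc1ccc([N+](=O)[O-])cc1`. In a functional assay on PC-3 cells (Homo sapiens) for inhibition (a lower number here means a stronger inhibitor of growth, a higher number a weaker inhibitor of growth), compound 1 gives > 100000 nM, which is a limit of the assay and not a number.
- compound 2 `O=C(COc1ccc(/C=C2\SC(=O)NC2=O)cc1)Nc1cccc([N+](=O)[O-])c1`. In this assay compound 2 gives > 100000 nM, again a limit of the assay rather than a number.
- compound 3 `O=C(COc1ccc(/C=C2\SC(=O)NC2=O)cc1)Nc1ccc(Cl)cc1`. In this assay compound 3 gives 83400 nM.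

Within the data shown here, compound 3 therefore stands as the only compound of the three with a number; the other two values sit at the limit of > 100000 nM in this assay, at which 2 of the 3 values shown sit. The step from compound 1 to compound 2 is a step that the two limits leave unreadable from compound 1 to compound 2. From compound 1 to compound 3 the step is an at least 1.1-fold lower number from compound 1 to compound 3 (0.07 log units; that floor lies within the scatter), and from compound 2 to compound 3 it is an at least 1.1-fold lower number from compound 2 to compound 3 (0.07 log units; that floor lies within the scatter); both floors lie within the scatter, so they say little about direction or size.

Compound 4 `Cc1cc(Br)ccc1NC(=O)COc1ccc(/C=C2\SC(=O)NC2=O)cc1` differs from compound 3 by 4-bromo-2-methylphenyl in place of 4-chlorophenyl on an amide-type nitrogen. Among the measured compounds shown here, the step that bears on this most closely is the one from compound 2 to compound 3, an exchange of the aryl group on the same amide-type nitrogen, and it is readable only as a floor. With a bromine in place of the chlorine and a methyl added, no step beyond the scatter is expected in this assay; the expected step from compound 3 to compound 4 is a 1.2-fold lower number from compound 3 to compound 4 (0.08 log units; within the scatter). Compound 4 is accordingly estimated at 70000 nM, within 25000 nM to 200000 nM, with a real chance that only a limit is returned.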

Compound 4, concentration for 50% growth inhibition: > 100000 nM
Compound 4: only a limit was reported (the forecaster's own chance of this, stated with the estimate: 40%); middle value at least 1.4-fold (0.15 log units) from the limit.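

In this assay, 4-bromo-2-methylphenyl in place of 4-chlorophenyl on the amide-type nitrogen gives an at least 1.1-fold higher number from compound 3 to compound 4 (0.07 log units; that floor lies within the scatter), so this change brings no readable gain or loss. The steps among compound 1, compound 2 and compound 4 join two limits and cannot be read. Of the four aryl groups on this nitrogen, only the 4-chlorophenyl of compound 3 returns a number, and the other three compounds share one limit: the limit of > 100000 nM in this assay, at which 3 of the 4 values shown sit.

Where the true values of compound 1, compound 2 and compound 4 lie remains open, and with them any order among these aryl groups. Also open, on these data alone, is whether an amine or a carboxylic acid on this aryl ring would give a number clearly lower than that of compound 3.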